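Moving a methoxy group on the phenylpropyl chain

The compounds below may be only part of what the source reports. "The series", "measured", "known", "first", "only" and "open" are said of these compounds alone.

Compound 3 `COc1cccc(CCCc2nc(N)c3nn(-c4ccccc4)cc3n2)c1` holds the lowest number among the three compounds measured in an assay on CHO cells for displacement of a labelled ligand from adenosine receptor A1 (Homo sapiens), read by scintillation counting (a higher number here means a weaker inhibitor, a lower number a stronger inhibitor), at 0.15 nM. Compound 1 `CCc1nc(N)c2nn(-c3ccccc3)cc2n1` gives 90 nM, and compound 2 `COc1ccc(CCc2nc(N)c3nn(-c4ccccc4)cc3n2)cc1` gives 380 nM. The step of a 600-fold lower number from compound 1 to compound 3 (2.78 log units; beyond the scatter) was large, whereas the step of a 4.2-fold higher number from compound 1 to compound 2 (0.63 log units; beyond the scatter) went the other way and was modest; the step of a 2500-fold lower number from compound 2 to compound 3 (3.40 log units; beyond the scatter) combines both a longer chain and a shifted methoxy group.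

Compound 4 `COc1ccc(CCCc2nc(N)c3nn(-c4ccccc4)cc3n2)cc1` differs from compound 3 only in 4-methoxyphenyl in place of 3-methoxyphenyl on a saturated chain carbon, three bonds along the chain from an aromatic carbon. Among the compounds with values here, no measured step isolates this change on the same chain, so the expectation leans on the observation that the 4-methoxyphenyl group in compound 2 did not lower the number while the 3-methoxybenzyl group in compound 3 did. Compound 4 is therefore expected to show a somewhat higher number in this assay, with the step of a 13-fold higher number from compound 3 to compound 4 (1.12 log units; beyond the scatter) anticipated to lie beyond the scatter but well short of the earlier large steps. The estimate for compound 4 is 2 nM, within a range of 0.3 nM to 20 nM.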

Compound 4, inhibition constant: 16 nM
Compound 4: middle estimate off by 8.0-fold (0.90 log units), on the low side, and the stated range covers the measured number.
By their numbers in this assay, from the lowest: compound 3; then compound 4; then compound 1; then compound 2.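

Taken alone, 4-methoxyphenyl in place of 3-methoxyphenyl on the saturated chain carbon gives a 110-fold higher number from compound 3 to compound 4 (2.03 log units; beyond the scatter) in this assay and so shows that where the methoxy group sits on this ring matters greatly by itself, which no earlier pair could isolate. With the methoxy group held in the same place, 4-methoxybenzyl in place of 4-methoxyphenyl gives a 24-fold lower number from compound 2 to compound 4 (1.38 log units; beyond the scatter) and so shows that the longer chain also counts on its own. The 4-methoxybenzyl group in place of hydrogen gives a 5.6-fold lower number from compound 1 to compound 4 (0.75 log units; beyond the scatter) and so lowers the number only modestly, far less than the 3-methoxybenzyl group does.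

The compounds shown leave open how a 3-methoxyphenyl group would fare on the shorter chain of compound 2, and how a hydroxy group in place of the methoxy group or a still longer chain would fare. Nothing given here accounts for the size of the methoxy shift.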